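The source may hold more compounds than are shown below. What is called first, only, known or untested is meant among the compounds shown, and "the series" means these compounds.

Working notes on the series. Within the data shown here, in an assay on isolated protein for inhibition of Apoptosis regulator Bcl-2 (Homo sapiens), read by fluorescence polarization (a higher number here means a weaker inhibitor, a lower number a stronger inhibitor), compound 2 `COc1ccccc1N1C(=O)/C(=C/c2ccc(OCc3ccc(C(=O)O)cc3)cc2)SC1=S` gives 2000 nM, the only number in the set. Compound 1 `Cc1ccccc1N1C(=O)/C(=C/c2ccc(OCC(=O)Nc3ccc(C(=O)O)cc3)cc2)SC1=S` gives > 10000 nM in this assay, which is a limit rather than a number. Compound 3 `Cc1cccc(N2C(=O)/C(=C/c3ccc(OCC(=O)Nc4ccc(C(=O)O)cc4)cc3)SC2=S)c1` gives > 10000 nM in this assay, again a limit. Among the measured compounds shown here, the single one-place step in the set, a step that the two limits leave unreadable from compound 1 to compound 3, is therefore unreadable, both ends resting on (the limit of > 10000 nM in this assay, at which 2 of the 3 values shown sit). For the measured compounds named here, compound 2 differs from compound 1 and from compound 3 in more than one place, so no step to it is computed.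

Compound 4 `O=C(O)c1ccc(COc2ccc(/C=C3\SC(=S)N(c4ccc(Cl)cc4)C3=O)cc2)cc1` is not yet measured. It differs from compound 2 by 4-chlorophenyl in place of 2-methoxyphenyl on an amide-type nitrogen in a ring. Going by the values given here, of the measured steps, only the one from compound 1 to compound 3 touches the same nitrogen, and its size cannot be read, so nothing in the set shows how far an exchange of the aryl group on this nitrogen moves the inhibition constant. The expectation for compound 4 rests on compound 2 at 2000 nM, with wide uncertainty. The step of a 1.5-fold higher number from compound 2 to compound 4 (0.18 log units; within the scatter) is estimated to stay within the scatter of this assay, with a real chance that compound 4 lands at the limit. Compound 4 is expected to give about 3000 nM in this assay, between 800 nM and 12000 nM.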

Compound 4, inhibition constant: > 10000 nM
Compound 4 was reported as a limit; the forecaster's own chance of this, stated with the estimate: 35%; at least 3.3-fold (0.52 log units) between middle value and limit.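

At the amide-type nitrogen in a ring, the set now holds its first readable step: in this assay, 4-chlorophenyl in place of 2-methoxyphenyl gives an at least 5.0-fold higher number from compound 2 to compound 4 (0.69 log units; beyond the scatter). The value of compound 4 is a limit and not a number, so the step has a floor but no measured size. The aryl group on this nitrogen therefore cannot be exchanged freely with the rest of compound 2 held constant, something the earlier step at this nitrogen could not show, as its size cannot be read, and the only number in the set remains that of compound 2, with the others resting on a single limit: the limit of > 10000 nM in this assay, at which 3 of the 4 values shown sit.

Going by these compounds, the step changes both the substituent and its place on the phenyl ring, so it remains open whether the chlorine, the loss of the methoxy group or the shift to the 4-position accounts for it. A 2-chlorophenyl or a 4-methoxyphenyl on the same nitrogen, with the rest of compound 2 kept, would separate these readings.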